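The source may hold more compounds than are shown below. What is called first, only, known or untested is meant among the compounds shown, and "the series" means these compounds.

Compound 2 `C=C(C)CN(C1=NCCN1)c1c(Br)cccc1Br` gives the lowest of the three numbers in a physicochemical assay for lipophilicity (a higher number here means a more lipophilic compound, a lower number a more polar compound), at -0.66. Compound 1 `Brc1ccc(Br)c(N(CC2CC2)C2=NCCN2)c1` stands within the scatter of it at -0.52, while compound 3 `Brc1cccc(Br)c1N(CC1CCC1)C1=NCCN1` gives -0.06, the change between them being a number 0.60 log units higher from compound 2 to compound 3 (beyond the scatter). Compound 4 `Brc1cccc(Br)c1N(C1=NCCN1)C1CCCCC1` differs from compound 2 by cyclohexyl in place of 2-methylprop-2-en-1-yl on a nitrogen on an aromatic ring. Among the measured compounds shown here, only the step from compound 2 to compound 3 bears on this change, and it was modest; here cyclohexyl enters with 6 heavy atoms where 2-methylprop-2-en-1-yl leaves with 4, and a rise in this assay at least as large is expected. Compound 4 is therefore estimated at 0.2, with a range from -0.3 to 0.7. That expectation amounts to a step of a number 0.86 log units higher from compound 2 to compound 4 (beyond the scatter).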

Compound 4, distribution coefficient: 0.14
Beside the measured number, compound 4's estimate is 0.06 log units above it, and the stated range covers the measured number.
By their numbers in this assay, from the lowest: compounds 2 and 1 (each within the scatter of the next); then compounds 3 and 4 (each within the scatter of the next).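

Replacing 2-methylprop-2-en-1-yl with cyclohexyl on a nitrogen on an aromatic ring gives a second rise in this assay, a number 0.80 log units higher from compound 2 to compound 4 (beyond the scatter), so the earlier rise now has a companion at this position. Cyclohexyl and cyclobutylmethyl cannot be told apart here, with a number 0.20 log units higher from compound 3 to compound 4 (within the scatter). Nothing at hand accounts for either rise. The compounds shown leave open how a chain ending in an amine or a carboxylic acid on this nitrogen would read in this assay. They also leave open how a phenyl ring there would compare with cyclohexyl.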